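This account rests on a few compounds, and the source may have more. Where it says the series, first, only, none or still open, it means among the compounds named here.

Measured in a functional assay on HT-29 cells (Homo sapiens) for inhibition, read by MTT assay, with a stated time of 72 h; on this read-out higher numbers stand for weaker inhibition and lower numbers for stronger inhibition:
compound 1 `COc1cc2c(Oc3ccc(NC(=O)c4nn(-c5ccccc5C)c(=O)cc4C)cc3F)ccnc2cc1OCCCN1CCCCC1`, 2810 nM
compound 2 `COc1cc2c(Oc3ccc(NC(=O)c4nn(-c5ccccc5C(F)(F)F)c(=O)cc4C)cc3F)ccnc2cc1OCCCN1CCCCC1`, 170 nM
compound 3 `COc1cc2c(Oc3ccc(NC(=O)c4nn(-c5cccc(F)c5)c(=O)cc4C)cc3F)ccnc2cc1OCCCN1CCCC1`, 250 nM

Compound 3 stands second highest of these three numbers; its value lies within the scatter of compound 2 and is separated from compound 1 by a gap beyond the scatter. Compound 4 `COc1cc2c(Oc3ccc(NC(=O)c4nn(-c5cccc(F)c5)c(=O)cc4C)cc3F)ccnc2cc1OCCCN1CCCCC1` differs from compound 3 by piperidin-1-yl in place of pyrrolidin-1-yl on a saturated chain carbon, three bonds along the chain from an oxygen on an aromatic ring. Going by the values given here, the one measured step, a 17-fold lower number from compound 1 to compound 2 (1.22 log units; beyond the scatter), concerns a different part of the molecule and does not bear on this change. Among the compounds with values here, compounds 1 and 2 already carry piperidin-1-yl, and no measured pair isolates the ring change on the chain. A step of no size beyond the scatter is therefore expected, no change at the digits printed from compound 3 to compound 4 (within the scatter). For compound 4 the estimate in this assay is 250 nM, in the range 100 nM to 600 nM.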

Compound 4, half-maximal inhibitory concentration: 290 nM
For compound 4 the middle estimate is 1.2-fold (0.06 log units) below the measured one, within the range that was stated.
By their numbers in this assay, from the lowest: compounds 2, 3 and 4 (each within the scatter of the next); then compound 1.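

In this assay, piperidin-1-yl in place of pyrrolidin-1-yl at the end of the propyl chain gives a 1.2-fold higher number from compound 3 to compound 4 (0.06 log units; within the scatter), so these two compounds do not separate the two rings. With piperidin-1-yl held fixed, 3-fluorophenyl in place of 2-(trifluoromethyl)phenyl on the aromatic nitrogen gives a 1.7-fold higher number from compound 2 to compound 4 (0.23 log units; within the scatter), while 3-fluorophenyl in place of 2-methylphenyl gives a 9.7-fold lower number from compound 1 to compound 4 (0.99 log units; beyond the scatter). No measurement at hand explains these steps.

Still open, as far as these compounds go, is whether morpholin-4-yl or dimethylamino at the chain end would read like these two rings. A longer chain carrying piperidin-1-yl is also untested in this set.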